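This account rests on a few compounds, and the source may have more. Where it says the series, first, only, none or still open, it means among the compounds named here.

Measured so far in an assay on blood for inhibition of C-X-C chemokine receptor type 3 (Homo sapiens), with a stated time of 30 min; on this read-out higher numbers stand for weaker inhibition and lower numbers for stronger inhibition: compound 1 `C[C@@H]1CN(c2scnc2-c2nc3ccccc3[nH]2)CCN1C(=O)Cn1cnc2cccnc21` gives 554 nM; compound 2 `C[C@@H]1CN(c2sc(C3COC3)nc2-c2nc3ccccc3[nH]2)CCN1C(=O)Cn1cnc2cccnc21` gives 1150 nM; compound 3 `Cc1nc(C)n(CC(=O)N2CCN(c3sc(C(F)(F)F)nc3-c3cnc(OC4CCC4)nc3)C[C@H]2C)n1` gives 306 nM.

Compound 3 gives the lowest of the three numbers in this assay, but its value and that of compound 1 lie within the usual scatter of each other, so neither can be called the stronger inhibitor on this evidence; only compound 2 stands apart from compound 3, beyond the scatter.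

Compound 4 `Cc1nc(C)n(CC(=O)N2CCN(c3sc(C(F)(F)F)nc3-c3ccc(C(F)(F)F)nc3)C[C@H]2C)n1` has not yet been measured. It differs from compound 3 in one place: 6-(trifluoromethyl)pyridin-3-yl in place of 2-(cyclobutyloxy)pyrimidin-5-yl on an aromatic carbon. For the measured compounds named here, the only step measured so far, a 2.1-fold higher number from compound 1 to compound 2 (0.32 log units; beyond the scatter), concerns a different position of the shared core and a different kind of group. It shows that a single modest change at the core can move the number beyond the scatter, but it says nothing direct about exchanging one aromatic ring for another at the position changed here. Going by the values given here, with no closer precedent, the expectation for compound 4 rests on compound 3 alone, and a step of a 1.5-fold higher number from compound 3 to compound 4 (0.17 log units; within the scatter) is expected, small enough that it may well stay within the scatter. Compound 4 is therefore estimated at 450 nM, with a range from 150 nM to 1500 nM.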

Compound 4, half-maximal inhibitory concentration: 860 nM
Estimate against measurement, compound 4: 1.9-fold (0.28 log units) below; the range from low to high includes it.
By their numbers in this assay, from the lowest: compounds 3, 1, 4 and 2 (each within the scatter of the next, the first and the last beyond it).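

In this assay, for the compounds shown here, putting 6-(trifluoromethyl)pyridin-3-yl in place of 2-(cyclobutyloxy)pyrimidin-5-yl gives a 2.8-fold higher number from compound 3 to compound 4 (0.45 log units; beyond the scatter), a modest loss of inhibition and the first reading at this aromatic carbon next to the ring nitrogen of the five-membered aromatic ring. The earlier step concerned a different position of the shared core, so this result adds that the group on this carbon can also move the number beyond the scatter. The exchange alters several things at once, removing the four-membered carbon ring and the oxygen, reducing the hydrogen-bond acceptors from 3 to 1 and bringing in fluorine, and no measurement here explains the change in the number.

The compounds shown leave open whether the step follows the six-membered aromatic ring or the group it carries: a pyridin-3-yl ring bearing cyclobutyloxy, or a pyrimidin-5-yl ring bearing trifluoromethyl, would separate the two. Also open, on these data alone, is how an amine or a carboxylic acid on that ring would read in this assay.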